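A methyl on the chain of compound 1

The source may report more compounds than this note shows. Statements on the series, on what has been measured and on what is new or still open speak of the compounds shown alone.

Of the compounds shown here, three sharing one core have been measured so far. In a functional assay on MCF7 cells (Homo sapiens) for antiproliferative activity, read by sulforhodamine B assay, with a stated time of 72 h (a higher number here means a weaker inhibitor, a lower number a stronger inhibitor), compound 1 `Cc1ccc(S(=O)(=O)Nc2cc(SCC(=O)N[C@@H](CC(C)C)B(O)O)c(O)c3ccccc23)cc1` gives 12800 nM, compound 2 `CC(C)C[C@H](NC(=O)CSc1cc(NS(=O)(=O)c2ccccc2)c2ccccc2c1O)B(O)O` gives 4160 nM and compound 3 `CC(=O)Nc1ccc(S(=O)(=O)Nc2cc(SCC(=O)N[C@@H](CC(C)C)B(O)O)c(O)c3ccccc23)cc1` gives 8660 nM. Compound 1 sits at the weak end of this small set, and the gap to its nearest neighbour is a 1.5-fold lower number from compound 1 to compound 3 (0.17 log units; within the scatter). Its furthest neighbour shows a 3.1-fold lower number from compound 1 to compound 2 (0.49 log units; beyond the scatter), and the remaining step is a 2.1-fold higher number from compound 2 to compound 3 (0.32 log units; beyond the scatter).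

Compound 4 `Cc1ccc(S(=O)(=O)Nc2cc(SC(C)C(=O)N[C@@H](CC(C)C)B(O)O)c(O)c3ccccc23)cc1` has not yet been measured. It differs from compound 1 by methyl in place of hydrogen on a saturated chain carbon bound to a carbonyl carbon and a sulfur. Among the measured compounds shown here, none of the measured steps touches that carbon. All three change a group on an aromatic carbon, so they serve only as a gauge of how far these numbers move after a small change. Those steps were modest or within the scatter, and they give no direction for a change on the chain. No step beyond the scatter is therefore expected in this assay, and the estimate is a 1.2-fold lower number from compound 1 to compound 4 (0.07 log units; within the scatter). For compound 4 the estimated value is 11000 nM, with an expected range from 4500 nM to 27000 nM.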

Compound 4, half-maximal inhibitory concentration: 8610 nM
The estimate for compound 4 lay 1.3-fold (0.11 log units) above the measured number; low and high end bracket the measured number.
By their numbers in this assay, from the lowest: compound 2; then compounds 4, 3 and 1 (each within the scatter of the next).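

Replacing hydrogen with methyl on a saturated chain carbon bound to a carbonyl carbon and a sulfur gives a 1.5-fold lower number from compound 1 to compound 4 (0.17 log units; within the scatter) in this assay, so at this carbon the added heavy atom leaves compound 4 indistinguishable from compound 1 in this read-out. The earlier steps shown here all concerned groups on an aromatic carbon, which makes this the first reading from the chain, and it shows that this position can carry a methyl without a difference beyond the usual variation between repeated measurements. No measurement here bears on why the two compounds cannot be told apart.

Going by these compounds, whether a longer chain such as ethyl or propyl at this carbon, or a different group such as an amine or a carboxylic acid, would separate from compound 1 remains open, since a single small group cannot show how much this position tolerates. Also open, on these data alone, is whether the same methyl would give a similar result on compound 2 or compound 3, which carry different groups on the aromatic carbon.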